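The source may report more compounds than this note shows. Statements on the series, on what has been measured and on what is new or still open speak of the compounds shown alone.

Compound 1 `Nc1cc(N)c2nc(-c3ccccc3)c(NCc3ccc(Cl)c(Cl)c3)nc2c1` gives 10700 nM in a functional assay on A549 cells (Homo sapiens) for inhibition, read by sulforhodamine B assay, with a stated time of 48 h; on this read-out higher numbers stand for weaker inhibition of growth and lower numbers for stronger inhibition of growth.
Compound 2 `COc1ccc(CNc2nc3cc(N)cc(N)c3nc2-c2ccccc2)cc1OC` gives 20900 nM.
Compound 3 `CCOC(=O)[C@H](CCC(=O)O)NC(=O)c1ccc(Sc2nc3cc(N)cc(N)c3nc2-c2ccccc2)cc1` gives 20400 nM.

Compound 2 thus stands at a number the other two do not separate from beyond the scatter: the change from compound 1 to compound 2 gave a 2.0-fold higher number from compound 1 to compound 2 (0.29 log units; within the scatter), and compound 3 shows almost the same value as compound 2. Compound 4 `COc1cc(CNc2nc3cc(N)cc(N)c3nc2-c2ccccc2)cc(OC)c1OC` differs from compound 2 in one place: methoxy in place of hydrogen on an aromatic carbon. Going by the values given here, no measured step adds a methoxy group to an aromatic ring; the only step available, a 2.0-fold higher number from compound 1 to compound 2 (0.29 log units; within the scatter), swapped one substituted ring for another and stayed within the scatter. With nothing pointing either way, compound 4 is expected to show a 1.0-fold lower number from compound 2 to compound 4 (0.02 log units; within the scatter), no step beyond the scatter. Compound 4 is estimated at 20000 nM, between 8000 nM and 50000 nM.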

Compound 4, concentration for 50% growth inhibition: 4270 nM
Estimate against measurement, compound 4: 4.7-fold (0.67 log units) above, outside the stated range (below it).
By their numbers in this assay, from the lowest: compound 4; then compounds 1, 3 and 2 (each within the scatter of the next).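

In this assay, methoxy in place of hydrogen on an aromatic carbon, ortho to a methoxy group, gives a 4.9-fold lower number from compound 2 to compound 4 (0.69 log units; beyond the scatter), which means stronger inhibition of growth. Going by these compounds alone, this is the first step here beyond the scatter, so this ring position responds to a change, while the swap of ring substituents in the earlier step did not separate its two compounds. No measurement shown offers an explanation for this step. Going by these compounds, whether a hydroxyl group, an ethoxy group or an amine at this position would act like methoxy stays open, as does whether the methoxy groups already on the ring are needed for the effect.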